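The source may report more compounds than this note shows. Statements on the series, on what has been measured and on what is new or still open speak of the compounds shown alone.

Compound 2 `CCCCCCCc1cc2c(=O)n(CC3CC3)cnc2s1` stands at the limit of an ADME assay on HCT-116 cells (Homo sapiens) for cytotoxicity, read by MTT assay, with a stated time of 11 days; a lower number here means a stronger inhibitor of growth, a higher number a weaker inhibitor of growth: compound 2 gives > 100 ug/mL, which is a limit of the measurement and not a number. Compound 1 `CCCCCCCc1cc2c(=O)n(CC#N)cnc2s1` gives > 100 ug/mL in this assay, also a limit. The step that the two limits leave unreadable from compound 1 to compound 2 therefore cannot be read, as both values sit at the limit of > 100 ug/mL in this assay, at which 2 of the 2 values shown sit. Compound 3 `CCCCCCCc1cc2c(=O)n(CCCBr)cnc2s1` carries 2-bromoethyl in place of cyclopropyl on a saturated chain carbon bound to an aromatic nitrogen. Within the data shown here, no measured step gives a readable size or direction for this change. Compound 3 is expected at 80 ug/mL, likely between 25 ug/mL and 150 ug/mL. That estimate amounts to an expected step of an at least 1.2-fold lower number from compound 2 to compound 3 (0.09 log units; that floor lies within the scatter), which may again end as a limit.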

Compound 3, concentration for 50% growth inhibition: > 100 ug/mL
Compound 3 was reported as a limit; the forecaster's own chance of this, stated with the estimate: 60%; at least 1.2-fold (0.09 log units) between middle value and limit.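

No new step can be read from compound 3: compound 1, compound 2 and compound 3 all stop at the same limit, not at a number: the limit of > 100 ug/mL in this assay, at which 3 of the 3 values shown sit. The compounds shown leave open whether any group at this place on the shared core gives a readable value in this assay.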